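The compounds below may be only part of what the source reports. "The series", "measured", "known", "first", "only" and "open" are said of these compounds alone.

Compound 1 `CC(C)C[C@@H]1C(=O)N[C@H](C2Cc3ccccc3C2)C(=O)N1[C@@H](C(=O)NC(C)C)c1ccccc1C(F)(F)F` is the reference point of this pair. In an assay on isolated protein for antagonist activity at Oxytocin receptor (Homo sapiens), read by FLIPR (a lower number here means a stronger inhibitor, a higher number a weaker inhibitor), compound 1 gives 31.6 nM, which is the higher of the two numbers available. Within the data shown here, its nearest neighbour is compound 2 `CCc1ccccc1[C@H](C(=O)NC(C)C)N1C(=O)[C@@H](C2Cc3ccccc3C2)NC(=O)[C@H]1CC(C)C`, which in this assay gives 15.9 nM; the single measured step, a 2.0-fold lower number from compound 1 to compound 2 (0.30 log units; within the scatter), is within the scatter, so the two compounds cannot be ordered.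

Compound 3 `CC(C)C[C@@H]1C(=O)N[C@H](C2Cc3ccccc3C2)C(=O)N1[C@@H](C(=O)NC(C)C)c1ccccc1-c1ccccc1` is not yet measured. Relative to compound 1 the change is phenyl in place of trifluoromethyl on an aromatic carbon. Among the measured compounds shown here, the only step that bears on it is the one from compound 1 to compound 2, where a different group was placed at the same aromatic carbon and the number moved by a 2.0-fold lower number from compound 1 to compound 2 (0.30 log units; within the scatter), within the scatter. For the measured compounds named here, no measured step covers a phenyl at this position, so the expectation rests on that one step alone and carries a wide range.

For compound 3 the estimate in this assay is 30 nM, with a range of 10 nM to 90 nM. The expected step is a 1.1-fold lower number from compound 1 to compound 3 (0.02 log units; within the scatter), which is no change beyond the scatter.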

Compound 3, inhibition constant: 39.8 nM
Estimate against measurement, compound 3: 1.3-fold (0.12 log units) below, and the stated range covers the measured number.
By their numbers in this assay, from the lowest: compounds 2, 1 and 3 (each within the scatter of the next, the first and the last beyond it).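

The aromatic carbon ortho to a large group can carry phenyl, with its six-membered aromatic ring and 6 heavy atoms, in place of trifluoromethyl without a change that can be read in this assay: a 1.3-fold higher number from compound 1 to compound 3 (0.10 log units; within the scatter), so these two groups cannot be ordered here. The series also now shows its first step beyond the scatter at this position, a 2.5-fold higher number from compound 2 to compound 3 (0.40 log units; beyond the scatter), a modest step that places ethyl ahead of phenyl, while compound 1, with trifluoromethyl, stays within the scatter of both and cannot be placed relative to either. No measurement available here bears on why the groups at this carbon differ in this way.

Going by these compounds, how an amine, a carboxylic acid, a methoxy group or a chain longer than ethyl would behave at this aromatic carbon remains open, as does whether a substituted phenyl would follow phenyl itself. On these data alone, all three compounds share the same remaining structure, so it is also open whether the step from ethyl to phenyl would hold with a different group elsewhere on the core.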